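Ester to amide on the chain of compound 2

A few compounds are considered here, and "the series" means these few. Any claim that something is new, unique, unknown or untested is made for them only; others in the source may bear on it.

Compound 1, `O=c1c2ccccc2c(-c2cccnc2)nn1Cc1ccccc1`, gives 97% in an assay on isolated protein (Oryctolagus cuniculus) with Thromboxane-A synthase (Homo sapiens) as the target, tested at 1 uM; on this read-out lower numbers stand for less inhibition and higher numbers for more inhibition at the one concentration tested (going by the name of the read-out). Compound 2, `CCOC(=O)CCCn1nc(-c2cccnc2)c2ccccc2c1=O`, gives 95% in this assay, so that the step of a number 2 percentage points lower from compound 1 to compound 2 (within the scatter). Among the two numbers known, compound 2 stands as the lower one, with compound 1 its only neighbour, and the two lie within the usual scatter of each other.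

Compound 3, `CC(C)NC(=O)CCCn1nc(-c2cccnc2)c2ccccc2c1=O`, is not yet measured. It differs from compound 2 in one place: isopropylamino in place of ethoxy on a carbonyl carbon. Within the data shown here, no measured step concerns a carbonyl carbon or an exchange of ethoxy for isopropylamino; the single measured step concerns a different place, the saturated chain carbon bound to an aromatic nitrogen, and it stayed within the scatter. There is thus nothing in the known numbers that points to a change beyond the scatter, and the shared core with its pyridyl group is kept in compound 3.

Compound 3 is therefore expected to show a number 2 percentage points lower from compound 2 to compound 3 (within the scatter) in this assay. The estimate for compound 3 is 93%, with a range from 80% to 99%.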

Compound 3, a percentage reported as inhibition, at one concentration (the size of the read-out at that concentration, not a potency): 89%
For compound 3 the middle estimate is 4 percentage points above the measured one; the range from low to high includes it.
By their numbers in this assay, from the lowest: compounds 3, 2 and 1 (each within the scatter of the next).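

Among these compounds, at the carbonyl carbon, which no earlier step had touched, the exchange of ethoxy for isopropylamino gives a number 6 percentage points lower from compound 2 to compound 3 (within the scatter) in this assay, so an ester can give way to an amide here, with a hydrogen-bond donor entering where ethoxy had none, without a step beyond the scatter. Read against the other end of the series, the change of phenyl to 2-(isopropylcarbamoyl)ethyl on the saturated chain carbon bound to an aromatic nitrogen gives a number 8 percentage points lower from compound 1 to compound 3 (within the scatter), so this amide chain, like the ester chain before it, cannot be told apart from compound 1 at the one concentration tested. Nothing at hand offers a reason for the size of either step, and no measurement bears on how these groups act.

Going by these compounds, what a carboxylic acid or a primary amide on the same carbonyl carbon would give remains open, as does the outcome for a longer chain between the aromatic nitrogen and the carbonyl. All three compounds were read at a single concentration, so whether they would separate at lower concentrations or in a full potency measurement is also unresolved.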